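Working notes: 3-nitrophenyl exchange on compound 3

The source may hold more compounds than are shown below. What is called first, only, known or untested is meant among the compounds shown, and "the series" means these compounds.

Measured so far in a functional assay on HeLa cells (Homo sapiens) for cytotoxicity, read by MTT assay, with a stated time of 24 h (on this read-out lower numbers stand for stronger inhibition and higher numbers for weaker inhibition), across three compounds:
- compound 1 `CN1C/C(=C\c2cccc([N+](=O)[O-])c2)C(=O)/C(=C/c2ccccc2F)C1` at 2340 nM
- compound 2 `COc1cc(/C=C2\CN(C)C/C(=C\c3ccc(C#N)cc3)C2=O)cc(OC)c1` at 3420 nM
- compound 3 `COc1cc(/C=C2\CN(C)C/C(=C\c3cc(OC)c(OC)c(OC)c3)C2=O)cc(OC)c1` at 2300 nM

Compound 3 at 2300 nM lies within the scatter of both compound 1 and compound 2, and the three values do not separate. The next member is compound 4 `COc1cc(/C=C2\CN(C)C/C(=C\c3cccc([N+](=O)[O-])c3)C2=O)cc(OC)c1OC` with 3-nitrophenyl in place of 3,5-dimethoxyphenyl on a double-bonded chain carbon bound to a double-bonded ring carbon and nothing else altered.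

Going by the values given here, no measured pair isolates this exchange. Compound 1 also carries 3-nitrophenyl and gives 2340 nM in this assay with a different group on its other side. Compound 2 also carries 3,5-dimethoxyphenyl and gives 3420 nM in the same test. Neither group stands apart on these values, and no change beyond the scatter is expected in either direction. The estimate is a 1.0-fold lower number from compound 3 to compound 4 (0.02 log units; within the scatter) and this expected step stays within the scatter. For compound 4 the expected value is 2200 nM with an estimated range from 1000 nM to 5000 nM in this test.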

Compound 4, half-maximal inhibitory concentration: 5540 nM
The estimate for compound 4 lay 2.5-fold (0.40 log units) below the measured number, outside the stated range (above it).
By their numbers in this assay, from the lowest: compounds 3, 1, 2 and 4 (each within the scatter of the next, the first and the last beyond it).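

In this assay, exchanging 3,5-dimethoxyphenyl for 3-nitrophenyl gives a 2.4-fold higher number from compound 3 to compound 4 (0.38 log units; beyond the scatter) and so weakens inhibition in this single pair. Going by these compounds alone, this shows that the position is not indifferent to the group it carries, which the earlier compounds, with their unseparated values and no pair differing in one place, could not show. No measurement of any property of these groups accompanies the step, so the result comes with no account of its origin.

Going by these compounds, whether the same exchange has a similar effect with a different group on the other side of the shared core remains open. Also open, on these data alone, is how an amine or a carboxylic acid on the aromatic ring at this position would compare with 3-nitrophenyl and 3,5-dimethoxyphenyl.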